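The source may hold more compounds than are shown below. What is called first, only, known or untested is meant among the compounds shown, and "the series" means these compounds.

Compound 1 `O=C(/C=C\Nc1cnc2ccccc2c1)c1nc(-c2ccccc2)n2ccccc12` gives 3780 nM in a functional assay on B16-F10 cells (Mus musculus) for cytotoxicity, read by MTT assay, with a stated time of 48 h (a higher number here means a weaker inhibitor, a lower number a stronger inhibitor), the highest of the two numbers obtained. Compound 3 `COc1ccc(N/C=C\C(=O)c2nc(-c3ccccc3)n3ccccc23)cc1` gives 1790 nM in this assay, and the step of a 2.1-fold lower number from compound 1 to compound 3 (0.32 log units; beyond the scatter) is modest. Compound 2 `COc1ccc(N/C=C\C(=O)c2nc(-c3ccc(F)cc3)n3ccccc23)cc1OC` reaches only a limit, > 30000 nM, in this assay (the limit of > 30000 nM in this assay, at which 1 of the 3 values shown sits). Compound 4 `O=C(/C=C\Nc1cnc2ccccc2c1)c1nc(-c2ccc(C(F)(F)F)cc2)n2ccccc12` differs from compound 1 by trifluoromethyl in place of hydrogen on an aromatic carbon, which read one bond further out is phenyl to 4-(trifluoromethyl)phenyl. Going by the values given here, no measured step alters that phenyl alone; the only step, a 2.1-fold lower number from compound 1 to compound 3 (0.32 log units; beyond the scatter), concerns the amine end. Compound 2, whose phenyl is substituted, differs from compound 3 in two places, so its limit gives no single-step guide. The author therefore expects compound 4 to give 6000 nM, between 2000 nM and 20000 nM. That estimate corresponds to an expected step of a 1.6-fold higher number from compound 1 to compound 4 (0.20 log units; within the scatter), modest at most.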

Compound 4, half-maximal inhibitory concentration: > 30000 nM
Compound 4 gave a limit, no number; the forecaster's own chance of this, stated with the estimate: 15%; middle value at least 5.0-fold (0.69 log units) from the limit.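

In this assay, the phenyl of the shared core proves sensitive to substitution: trifluoromethyl in place of hydrogen on this aromatic carbon, para to a large group, gives an at least 7.9-fold higher number from compound 1 to compound 4 (0.89 log units; beyond the scatter). Going by these compounds alone, the earlier single-place comparison covered only the amine end, so this is the first clean reading at this position. Compound 4 gives a limit and not a number, so the full size of the step stays unknown: the limit of > 30000 nM in this assay, at which 2 of the 4 values shown sit.

The compounds shown leave open whether methyl or hydroxyl at this place would be tolerated. They also leave open whether trifluoromethyl has the same effect with the 4-methoxyphenyl group of compound 3.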